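The source may report more compounds than this note shows. Statements on the series, on what has been measured and on what is new or still open speak of the compounds shown alone.

Measured compounds:
- Compound 1 `Cc1cn(-c2cc(NC(=O)c3ccc(C)c(Nc4nc(-c5cccnc5)cs4)c3)cc(C(F)(F)F)c2)cn1`: 28 nM
- Compound 2 `Cc1ncn(-c2cc(NC(=O)c3ccc(C)c(Nc4nc(-c5cccnc5)cs4)c3)cc(C(F)(F)F)c2)n1`: 26 nM

Both compounds were tested in a functional assay on K562 cells (Homo sapiens) for antiproliferative activity; on this read-out lower numbers stand for stronger inhibition and higher numbers for weaker inhibition. Compound 1 gives 28 nM and compound 2 gives 26 nM; the step of a 1.1-fold lower number from compound 1 to compound 2 (0.03 log units; within the scatter) lies within the scatter, so the two numbers cannot be told apart. Compound 2 thus holds the lower of the two numbers only by a margin that means nothing.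

Compound 3 `Cc1ccc(C(=O)Nc2cc(-c3cnn(C)c3)cc(C(F)(F)F)c2)cc1Nc1nc(-c2cccnc2)cs1` has not yet been measured. It differs from compound 2 in one place: 1-methyl-1H-pyrazol-4-yl in place of 3-methyl-1H-1,2,4-triazol-1-yl on an aromatic carbon. Going by the values given here, the only step known so far, from compound 1 to compound 2, also swapped one small five-membered ring for another at this same spot and produced no change beyond the scatter. Among the compounds with values here, that step gives a hint, not a rule, since the ring in compound 3 is attached through a carbon rather than a nitrogen and carries one fewer hydrogen-bond acceptor, a kind of swap no measured pair covers. On this thin basis, compound 3 is expected to land close to compound 2, with the step of a 1.2-fold higher number from compound 2 to compound 3 (0.06 log units; within the scatter) expected to stay within the scatter. The estimate for compound 3 in this assay is 30 nM, with a range from 10 nM to 90 nM.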

Compound 3, half-maximal inhibitory concentration: 27 nM
Compound 3: the middle estimate sits 1.1-fold (0.05 log units) above what was measured; the range from low to high includes it.
By their numbers in this assay, from the lowest: compounds 2, 3 and 1 (each within the scatter of the next).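

The earlier pair only compared two rings joined to the aromatic carbon through a nitrogen, whereas compound 3 places a ring joined through a carbon at the same spot, and in this assay this makes no measurable difference, with a 1.0-fold higher number from compound 2 to compound 3 (0.02 log units; within the scatter) and with a 1.0-fold lower number from compound 1 to compound 3 (0.02 log units; within the scatter) as well. The entering 1-methyl-1H-pyrazol-4-yl also has 2 hydrogen-bond acceptors where the departing 3-methyl-1H-1,2,4-triazol-1-yl has 3, so across compounds 1, 2 and 3 neither the attachment atom nor this change in acceptor count separates the numbers, and the three compounds cannot be ranked. Nothing available here explains why these swaps leave the read-out flat.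

All three groups are methyl-bearing five-membered aromatic rings, so these results say nothing about how far the flat picture extends to very different groups at this position, such as a carboxylic acid, a longer chain ending in an amine, or a plain hydrogen. On these data alone, it also remains open whether moving the methyl group to another atom of the ring, or removing it, would keep the number in the same range.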